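The source may hold more compounds than are shown below. What is called first, only, known or untested is meant among the compounds shown, and "the series" means these compounds.

Working notes on the benzyl-substituted purine series. Compound 1 `ClCc1cccc(Cn2cnc3ncnc(Cl)c32)c1` carries no result in a functional assay on HOP-92 cells (Homo sapiens) for cytotoxicity, read by sulforhodamine B assay, with a stated time of 48 h; a lower number here means a stronger inhibitor of growth, a higher number a weaker inhibitor of growth; for compound 1 the entry is recorded as "not determined" (no result reported). Compound 2 `ClCc1ccc(Cn2cnc3nc(Cl)nc(Cl)c32)cc1` likewise carries no result, and for compound 2 the entry is recorded as "not determined" (no result reported), so compound 2 stands nowhere on the numbers. Within the data shown here, the only measured member is compound 3 `Nc1nc(Cl)c2ncn(Cc3cccc(CCl)c3)c2n1`, which in this assay gives 38000 nM, a weak growth inhibitor. Among the measured compounds shown here, no pair of measured compounds differs in a single place, so no measured step is available to calibrate the series.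

Compound 4 `ClCc1ccc(Cn2cnc3ncnc(Cl)c32)cc1` is the next candidate for this assay. Relative to compound 2 the change is hydrogen in place of chloro on an aromatic carbon, that is, one chloro group removed from the aromatic carbon between two ring nitrogen atoms of the fused system. With compound 2 itself unquantified, the size and direction of this step cannot be stated beyond the scatter; the only anchor is the weak activity of compound 3, whose value 38000 nM suggests the whole set sits in the high-concentration range. Compound 4 is therefore expected near 30000 nM, in a range of 8000 nM to 100000 nM.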

Compound 4, concentration for total growth inhibition: 2510 nM
Estimate against measurement, compound 4: 12-fold (1.08 log units) above; the measured number lies below the stated range.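

No step can be read from compound 2 to compound 4: compound 2 has no single number in this assay. The compounds shown leave open what the chloro group between two ring nitrogen atoms contributes to growth inhibition. Nothing available explains the result.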